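The source may report more compounds than this note shows. Statements on the series, on what has been measured and on what is new or still open speak of the compounds shown alone.

In an ADME assay on BJ cells (Homo sapiens) for cytotoxicity, with a stated time of 72 h (a lower number here means that less compound is needed, a higher number that more compound is needed for the effect), compound 1 `O=C(Nc1cccc(-c2nc3ccccc3s2)c1)c1cc([N+](=O)[O-])ccc1Cl` gives > 27000 nM, and that value is a limit of the assay rather than a number. Compound 2 `O=C(Nc1ccc(F)c(-c2nc3ccccc3s2)c1)c1cc([N+](=O)[O-])ccc1Cl`, which carries fluoro in place of hydrogen on an aromatic carbon, gives > 25000 nM in this assay, again a limit. Compound 3 `O=C(Nc1ccc(Cl)c(-c2nc3ccccc3s2)c1)c1cc([N+](=O)[O-])ccc1Cl`, with chloro in place of hydrogen on an aromatic carbon, gives > 25000 nM in this assay, also a limit. Because all three values are limits, the steps a step that the two limits leave unreadable from compound 1 to compound 2, a step that the two limits leave unreadable from compound 1 to compound 3 and a step that the two limits leave unreadable from compound 2 to compound 3 cannot be read in size; compound 3 therefore stands at the limit of > 25000 nM in this assay, at which 2 of the 3 values shown sit, with no number of its own.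

Compound 4 `O=C(Nc1ccc(Cl)cc1)c1cc([N+](=O)[O-])ccc1Cl` differs from compound 3 in one place: hydrogen in place of 1,3-benzothiazol-2-yl on an aromatic carbon. Within the data shown here, none of the measured steps touches this part of the shared core, so nothing among them bears on the change, and no direction can be taken from them. Given that compound 3 sits at the limit of > 25000 nM in this assay, at which 2 of the 3 values shown sit, the step from compound 3 to compound 4 is expected to be a step that the limit leaves unreadable from compound 3 to compound 4, that is, to stay within the scatter, most likely with another limit. Compound 4 is thus expected to give about 30000 nM in this assay, within a range from 10000 nM to 100000 nM.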

Compound 4, half-maximal effective concentration: > 27000 nM
Compound 4 ended at the assay's limit; the forecaster's own chance of this, stated with the estimate: 80%; the middle value does not contradict the limit.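

Compound 3 and compound 4 each give a limit of the assay rather than a number, so the step between them, with hydrogen in place of 1,3-benzothiazol-2-yl, cannot be read in size. The compounds shown leave open at what concentration any of them would reach the half-maximal effect in this assay.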